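The source may report more compounds than this note shows. Statements on the series, on what has been measured and on what is new or still open speak of the compounds shown alone.

Working notes on the series. Compound 1 `O=C(Nc1cccc(-n2cc(-c3ccncc3)c(-c3cc(O)cc(Cl)c3)n2)c1)Nc1ccc(Cl)c(Cl)c1` and compound 2 `COc1cc(Cl)cc(-c2nn(-c3cccc(NC(=O)Nc4ccc(Cl)c(Cl)c4)c3)cc2-c2ccncc2)c1` share one core and differ in a single place. In a functional assay on LOX IMVI cells (Homo sapiens) for inhibition, read by sulforhodamine B assay, with a stated time of 48 h, tested at 0.1 uM (on this read-out lower numbers stand for a stronger effect and higher numbers for a weaker effect at the one concentration tested), compound 1 gives 105%, while compound 2 gives 94%. Within the data shown here, the one measured step is a number 11 percentage points lower from compound 1 to compound 2 (beyond the scatter). On the numbers shown, compound 2 stands lowest of the two, with compound 1 the nearest at a number higher by a margin beyond the scatter.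

Compound 3 `COc1cc(Cl)cc(-c2nn(-c3cccc(NC(=O)c4cccc(C(F)(F)F)c4)c3)cc2-c2ccncc2)c1` is not yet measured. It differs from compound 2 on a carbonyl carbon whose other neighbour is an amide-type nitrogen: 3-(trifluoromethyl)phenyl in place of (3,4-dichlorophenyl)amino on a carbonyl carbon. Among the measured compounds shown here, no measured step bears on this change; the only step available concerns a methyl in place of hydrogen on an oxygen on an aromatic ring, a different kind of change, so it offers no direction. Both measured numbers in this assay sit close together near the top of the scale, and the remainder of compound 2 is kept intact, so the expected step is a number 3 percentage points higher from compound 2 to compound 3 (within the scatter), none beyond the scatter. For compound 3 the estimate in this assay is 97%, between 85% and 110%.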

Compound 3, a percentage reported as activity, at one concentration (the size of the read-out at that concentration, not a potency): 95%
For compound 3 the middle estimate is 2 percentage points above the measured one; low and high end bracket the measured number.
By their numbers in this assay, from the lowest: compounds 2, 3 and 1 (each within the scatter of the next, the first and the last beyond it).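

Among these compounds, the first reading on the carbonyl carbon whose other neighbour is an amide-type nitrogen is a number 1 percentage points higher from compound 2 to compound 3 (within the scatter) in this assay, so this position can take a change of group, not only the change on the aromatic oxygen seen earlier. Here 3-(trifluoromethyl)phenyl in place of (3,4-dichlorophenyl)amino swaps both the substituents on the aromatic ring and the link to that ring, including the hydrogen-bond donor counted on the leaving group, and the read-out at the one concentration tested shows no difference beyond the scatter. Nothing available gives a reason for this reading.

Still open, as far as these compounds go, is whether any group on this carbonyl carbon separates from compound 2 at all, for example a piperidine amine, a carboxylic acid or a longer alkyl chain in place of the aromatic ring. Also open, from the compounds shown here alone, is whether a higher concentration would tell compound 2 and compound 3 apart, since a single-concentration read-out gives no potency for either of them.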